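A few compounds are considered here, and "the series" means these few. Any claim that something is new, unique, unknown or untested is made for them only; others in the source may bear on it.

In a functional assay on MCF7 cells (Homo sapiens) for antiproliferative activity (on this read-out lower numbers stand for stronger inhibition and higher numbers for weaker inhibition), compound 1 `CC(C)=CCc1cc(C(=O)Nc2cc3ccc(OCCCNC(C)(C)C)c(C)c3oc2=O)ccc1O` gives 950 nM and compound 2 `CC(C)=CCc1cc(C(=O)Nc2cc3ccc(OCCCN(C)C(C)(C)C)c(C)c3oc2=O)ccc1O` gives 1140 nM, which is a 1.2-fold higher number from compound 1 to compound 2 (0.08 log units; within the scatter). Compound 3 `CC(C)=CCc1cc(C(=O)Nc2cc3ccc(OCCCNCC(=O)O)c(C)c3oc2=O)ccc1O`, at 18100 nM, has the highest number of the three. Going to compound 4 `CC(C)=CCc1cc(C(=O)Nc2cc3ccc(OCCCNc4ccccc4)c(C)c3oc2=O)ccc1O` puts phenyl in place of carboxymethyl on an amine nitrogen. The relevant measured steps are a 19-fold higher number from compound 1 to compound 3 (1.28 log units; beyond the scatter) and a 16-fold higher number from compound 2 to compound 3 (1.20 log units; beyond the scatter), both large and both ending on the carboxymethyl compound. Among the compounds with values here, no measured compound carries phenyl, so the size of the recovery is uncertain. A large move to lower numbers in this assay is expected, stopping short of the values of the first two compounds. The expected step is a 9.1-fold lower number from compound 3 to compound 4 (0.96 log units; beyond the scatter). For compound 4 the estimated value is 2000 nM, with an expected range of 600 nM to 7000 nM.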

Compound 4, half-maximal inhibitory concentration: > 50000 nM
Compound 4 ended at the assay's limit (the forecaster's own chance of this, stated with the estimate: 5%); middle value at least 25-fold (1.39 log units) away from the limit.
By their numbers in this assay, from the lowest: compounds 1 and 2 (each within the scatter of the next); then compound 3. At a limit, above all of these: compound 4.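

In this assay, phenyl on this amine nitrogen raises the number past carboxymethyl (an at least 2.7-fold higher number from compound 3 to compound 4 (0.44 log units; beyond the scatter)) and well past the tert-butyl pair (an at least 43-fold higher number from compound 2 to compound 4 (1.64 log units; beyond the scatter)) (an at least 52-fold higher number from compound 1 to compound 4 (1.72 log units; beyond the scatter)). The loss at this nitrogen is therefore not tied to carboxymethyl alone, since phenyl, with 0 hydrogen-bond donors and 0 hydrogen-bond acceptors, also gives it. The value for compound 4 is a limit and not a number: the limit of > 50000 nM in this assay, at which 1 of the 4 values shown sits.

Open, going by these compounds, is whether a benzyl or cyclohexyl group on this nitrogen stays near compounds 1 and 2. Also open, on these data alone, is whether a simple dimethylamine or a longer chain holds those values.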